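The source may report more compounds than this note shows. Statements on the series, on what has been measured and on what is new or still open speak of the compounds shown alone.

Measured so far in an ADME assay on microsomes from liver (Homo sapiens) for metabolic stability, read by LC-MS, using NADPH, tested at 5 uM; a higher number here means that the compound lasts longer, a lower number that the compound disappears faster: compound 1 `Cc1cc(S(=O)(=O)/N=C(\N)N/N=C/C#Cc2ccccc2)c(SCc2ccccc2C)cc1Cl` gives 0.862 h; compound 2 `C/C(C#Cc1ccccc1)=N\N/C(N)=N/S(=O)(=O)c1cc(C)c(Cl)cc1SCc1ccc(C(F)(F)F)cc1` gives 1.41 h; compound 3 `C/C(C#Cc1ccccc1)=N\N/C(N)=N/S(=O)(=O)c1cc(C)c(Cl)cc1SCc1ccccc1Cl` gives 1.42 h.

Compound 1 stands within the scatter of both compound 2 and compound 3, so the three cannot be told apart on these numbers. The step to compound 4 `Cc1cc(S(=O)(=O)/N=C(\N)N/N=C/C#Cc2ccccc2)c(SCc2cccc3ccccc23)cc1Cl` is naphthalen-1-yl in place of 2-methylphenyl on a saturated chain carbon bound to a sulfur. Among the measured compounds shown here, the one measured step at the same place, a 1.0-fold higher number from compound 2 to compound 3 (0.00 log units; within the scatter), exchanged one aryl group on that carbon for another and moved nothing beyond the scatter. That step bears directly on the present one, although the entering group here is larger, as the counted difference shows. Compound 4 is therefore expected to stay close to compound 1 in this assay, with an expected step of a 1.0-fold higher number from compound 1 to compound 4 (0.02 log units; within the scatter). The estimate for compound 4 is 0.9 h, within a range from 0.45 h to 1.8 h.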

Compound 4, half-life: 1.2 h
Compound 4: middle estimate off by 1.3-fold (0.12 log units), on the low side, within the range that was stated.
By their numbers in this assay, from the lowest: compounds 1, 4, 2 and 3 (each within the scatter of the next).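

In this assay, the change to naphthalen-1-yl gives a 1.4-fold higher number from compound 1 to compound 4 (0.14 log units; within the scatter). The earlier step at this place, on a saturated chain carbon bound to a sulfur, only exchanged one phenyl group for another, whereas this one brings in a second six-membered aromatic ring and the value still stays within the scatter. Nothing available bears on the reason for this result. Still open, as far as these compounds go, is whether a group of another kind on this carbon, such as an amine or a carboxylic acid, would also stay within the scatter, and whether a longer chain would.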